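Compound 3 to compound 4: isopropyl becomes 2-methylbutyl

A few compounds are considered here, and "the series" means these few. Any claim that something is new, unique, unknown or untested is made for them only; others in the source may bear on it.

In a functional assay on HepG2 cells (Homo sapiens) for cytotoxicity, read by MTT assay (on this read-out higher numbers stand for weaker inhibition and lower numbers for stronger inhibition), compound 1 (`COc1cc(CCCCC(C)(C)O)oc(=O)c1C`) gives > 200000 nM as a limit. For compound 2 (`CC(=O)C(C)CCCCc1cc(O)c(C)c(=O)o1`) the reading is > 200000 nM and this too is a limit. For compound 3 (`Cc1c(O)cc(CCCC(C)C)oc1=O`) the reading is > 200000 nM and this is again a limit, so compound 3 has no number of its own and stands level with the other two only as far as their limits can say.

The next structure is compound 4 (`CCC(C)CCCCc1cc(O)c(C)c(=O)o1`), which carries 2-methylbutyl in place of isopropyl on a saturated chain carbon, three bonds along the chain from an aromatic carbon. For the measured compounds named here, one measured step touches the same place, namely a step that the two limits leave unreadable from compound 2 to compound 3 with isopropyl in place of 2-acetylpropyl. Going by the values given here, its size stays open because of the limit of > 200000 nM in this assay, at which 3 of the 3 values shown sit, and no compound in the set gives a number to compare with.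

The data therefore offer no reason to expect a move in either direction beyond the scatter. The expected change is a number no higher from compound 3 to compound 4 (the limit leaves the size open) and this estimate means no real shift. Compound 4 is estimated at about 200000 nM with an expected range of 100000 nM to 400000 nM in this assay and will most likely be reported as a limit again.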

Compound 4, half-maximal inhibitory concentration: > 200000 nM
Compound 4 was reported as a limit; the forecaster's own chance of this, stated with the estimate: 85%; the middle value sits exactly at the limit.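

Compound 4 comes out as a limit too, so the steps that lead to it from compound 2 and from compound 3 cannot be read, and no size can be given for either: the limit of > 200000 nM in this assay, at which 4 of the 4 values shown sit.

The compounds shown leave open whether any of these side chains on the shared core reaches a true number in this assay.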